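Iodo for ethyl on the aromatic carbon: compound 3

The source may report more compounds than this note shows. Statements on the series, on what has been measured and on what is new or still open speak of the compounds shown alone.

Compound 1 `CCc1ccc(-n2cc(COc3cccc(NC(=O)Nc4ccc(Cl)c(C(F)(F)F)c4)c3)nn2)cc1` is the reference point of this pair. In a functional assay on HepG2 cells (Homo sapiens) for inhibition, read by MTT assay, with a stated time of 72 h (a lower number here means a stronger inhibitor, a higher number a weaker inhibitor), compound 1 gives 1950 nM; compound 2 `O=C(Nc1cccc(OCc2cn(-c3ccccc3I)nn2)c1)Nc1ccc(Cl)c(C(F)(F)F)c1` gives 2870 nM, and the two sit within the scatter of each other, so neither can be set apart. The step of a 1.5-fold higher number from compound 1 to compound 2 (0.17 log units; within the scatter) comes from 2-iodophenyl in place of 4-ethylphenyl on an aromatic nitrogen.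

Compound 3 `O=C(Nc1cccc(OCc2cn(-c3ccc(I)cc3)nn2)c1)Nc1ccc(Cl)c(C(F)(F)F)c1` differs from compound 1 by iodo in place of ethyl on an aromatic carbon. Going by the values given here, the only measured step that bears on it is the one from compound 1 to compound 2, which also brings in iodo, though at a different place and together with loss of ethyl, and it stays inside the scatter. Among the compounds with values here, no measured step isolates iodo for ethyl at the place concerned. The expected change is therefore a 1.2-fold higher number from compound 1 to compound 3 (0.07 log units; within the scatter), nothing beyond the scatter. Compound 3 is estimated at 2300 nM, within 1100 nM to 4800 nM.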

Compound 3, half-maximal inhibitory concentration: 2690 nM
Beside the measured number, compound 3's estimate is 1.2-fold (0.07 log units) below it, and the stated range covers the measured number.
By their numbers in this assay, from the lowest: compounds 1, 3 and 2 (each within the scatter of the next).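

In this assay, going by these compounds alone, iodo in place of ethyl on this aromatic carbon gives a 1.4-fold higher number from compound 1 to compound 3 (0.14 log units; within the scatter), the first reading that isolates this change, and it does not set the two groups apart. Within the data shown here, compound 3 also allows the first comparison of two iodo placements: 4-iodophenyl in place of 2-iodophenyl gives a 1.1-fold lower number from compound 2 to compound 3 (0.03 log units; within the scatter), so these two placements cannot be told apart in this read-out either. No supporting data bear on these readings.

The compounds shown leave open whether a different kind of group at this place, such as an amine or a carboxylic acid, would give a step beyond the scatter. Also open, on these data alone, is whether a longer chain in place of ethyl would stay within the scatter of compound 1.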